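Replacing the Tetrazolylmethyl Group: Expected Stability of Compound 4

A few compounds are considered here, and "the series" means these few. Any claim that something is new, unique, unknown or untested is made for them only; others in the source may bear on it.

Compound 1 `CC(C)C(c1ncco1)c1ccc(-c2ccc3cccc(F)c3c2)[nH]c1=O`: 0.178 h
Compound 2 `CC(C)C(c1nnc[nH]1)c1ccc(-c2ccc3cccc(F)c3c2)[nH]c1=O`: 0.905 h
Compound 3 `CC(C)C(Cc1nnn[nH]1)c1ccc(-c2ccc3cccc(F)c3c2)[nH]c1=O`: > 3 h (a limit of the assay)

Three compounds share one core and differ only in the group on a saturated chain carbon bound to an aromatic carbon and a saturated chain carbon. In an ADME assay on microsomes from liver (Homo sapiens) for metabolic stability (on this read-out higher numbers stand for a longer-lived compound and lower numbers for a shorter-lived compound), compound 1 gives 0.178 h and compound 2 gives 0.905 h. For compound 3 this assay reports only a limit, > 3 h, so compound 3 stands at the top of the numbers shown, at the limit of > 3 h in this assay, at which 1 of the 3 values shown sits. The measured steps are a 5.1-fold higher number from compound 1 to compound 2 (0.71 log units; beyond the scatter), an at least 16-fold higher number from compound 1 to compound 3 (1.22 log units; beyond the scatter) and an at least 3.3-fold higher number from compound 2 to compound 3 (0.52 log units; beyond the scatter).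

Compound 4 `CC(C)C(/C=C1/CCNC1=O)c1ccc(-c2ccc3cccc(F)c3c2)[nH]c1=O` differs from compound 3 in one place: a group of 7 heavy atoms (5 carbon, 1 nitrogen, 1 oxygen; one five-membered non-aromatic ring with 1 hetero atom) in place of a group of 6 heavy atoms (2 carbon, 4 nitrogen; one five-membered aromatic ring with 4 hetero atoms), on a saturated chain carbon bound to an aromatic carbon and a saturated chain carbon. Within the data shown here, no measured step contains the entering group, so the three steps bear on it only by showing that the departing 1H-tetrazol-5-yl)methyl group sat above both the 1,3-oxazol-2-yl and 4H-1,2,4-triazol-3-yl alternatives. A downward step in this assay is therefore expected, of uncertain size. Compound 4 is expected to give about 1 h, within 0.3 h to 3 h. That estimate corresponds to an expected step of an at least 3.0-fold lower number from compound 3 to compound 4 (0.47 log units; beyond the scatter).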

Compound 4, half-life: 0.987 h
Compound 4: middle estimate off by 1.0-fold (0.01 log units), on the high side; measured number inside the range.
By their numbers in this assay, from the lowest: compound 1; then compounds 2 and 4 (each within the scatter of the next). At a limit, above all of these: compound 3.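

In this assay, an entering group with a five-membered non-aromatic ring still gives a 5.5-fold higher number from compound 1 to compound 4 (0.74 log units; beyond the scatter), so an aromatic ring at this place is not required for a rise over the 1,3-oxazol-2-yl group. The same group gives a 1.1-fold higher number from compound 2 to compound 4 (0.04 log units; within the scatter), which leaves it level with 4H-1,2,4-triazol-3-yl, while its exchange for (1H-tetrazol-5-yl)methyl gives an at least 3.0-fold lower number from compound 3 to compound 4 (0.48 log units; beyond the scatter). The value of compound 3 is a limit and not a number, so this last step has a floor only: the limit of > 3 h in this assay, at which 1 of the 4 values shown sits.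

The compounds shown leave open which part of the entering group, the ring, the double bonds or the carbonyl, goes with its number. They also leave open whether a carboxylic acid or an amine on this saturated chain carbon would match compound 3.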